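Adding a Fluoro Group to a Weak Cytotoxic Series

The source may report more compounds than this note shows. Statements on the series, on what has been measured and on what is new or still open speak of the compounds shown alone.

Measured compounds, each tested in a functional assay on MCF7 cells (Homo sapiens) for cytotoxicity, read by MTT assay, with a stated time of 72 h; a lower number here means a stronger inhibitor, a higher number a weaker inhibitor:
compound 1, `O=C(Nc1ccc(Oc2ccnc3[nH]ccc23)cc1)c1nn(-c2ccc(Br)cc2)ccc1=O`, gives 7890 nM
compound 2, `O=C(Nc1ccc(Oc2ccnc3[nH]ccc23)c(F)c1)c1nn(-c2ccc(Br)cc2)ccc1=O`, gives 11600 nM
compound 3, `Cc1cc(=O)n(-c2ccccc2OC(F)(F)F)nc1C(=O)Nc1ccc(Oc2ncnc3c2ccn3C)cc1`, gives 27000 nM

Compound 2 differs from compound 1 by fluoro in place of hydrogen on an aromatic carbon. The result was a 1.5-fold higher number from compound 1 to compound 2 (0.17 log units; within the scatter), so the two compounds cannot be told apart on this measure. Compound 3 is built on a different core; the difference between the two cores is not broken down here. Among the three measured compounds, compound 3 shows the highest number.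

Compound 4, `Cc1cc(=O)n(-c2ccccc2OC(F)(F)F)nc1C(=O)Nc1ccc(Oc2ncnc3c2ccn3C)c(F)c1`, has not yet been measured. It differs from compound 3 by fluoro in place of hydrogen on an aromatic carbon. Going by the values given here, this is the same change as the one from compound 1 to compound 2, made at the same kind of place. Since that earlier step stayed within the scatter, the expectation for compound 4 is an estimated step of a 1.4-fold higher number from compound 3 to compound 4 (0.15 log units; within the scatter), resting on compound 3 giving 27000 nM and on the measured step of a 1.5-fold higher number from compound 1 to compound 2 (0.17 log units; within the scatter). In this assay compound 4 is therefore expected to give about 38000 nM, estimated to fall between 15000 nM and 95000 nM.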

Compound 4, half-maximal inhibitory concentration: > 60000 nM
Compound 4 ended at the assay's limit; the forecaster's own chance of this, stated with the estimate: 20%; middle value at least 1.5-fold (0.19 log units) from the limit.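

In this assay compound 4 gives > 60000 nM, which is a limit of the assay and not a number. On the core of compound 3, fluoro in place of hydrogen gives an at least 2.2-fold higher number from compound 3 to compound 4 (0.34 log units; beyond the scatter), a step beyond the scatter even at this limit, whereas the same change on the core of compound 1 gives a 1.5-fold higher number from compound 1 to compound 2 (0.17 log units; within the scatter). This shows that the change can carry a measurable cost on at least one core, but it does not show that the two cores truly respond differently to it: the same change on two cores in this assay, a 1.5-fold higher number (0.17 log units; within the scatter) from compound 1 to compound 2 and an at least 2.2-fold higher number (0.34 log units; beyond the scatter) from compound 3 to compound 4; the limit leaves it open whether they differ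

Going by these compounds alone, with only two pairs on two cores, nothing here tells how the change would fare on a third core. On these data alone, whether a chloro group, a methoxy group or an amine on that same aromatic carbon would behave like fluoro also stays open.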